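The source may report more compounds than this note shows. Statements on the series, on what has been measured and on what is new or still open speak of the compounds shown alone.

Compound 2 `O=C(CN1CC(CO)=CC[C@H](NC(=O)c2ccc3ccccc3c2)C1=O)N[C@H]1CC(=O)OC1O` is one of two compounds tested in an assay on isolated protein for inhibition of Caspase-8 (Homo sapiens); a higher number here means a weaker inhibitor, a lower number a stronger inhibitor; there compound 2 gives 2110 nM, while compound 1 `O=C(CN1CC=CC[C@H](NC(=O)c2cccc(Cl)c2)C1=O)N[C@H]1CC(=O)OC1O` gives 1180 nM, and the two numbers lie within the scatter of each other. Compound 3 `O=C(CN1CC=CC[C@H](NC(=O)c2ccc3ccccc3c2)C1=O)N[C@H]1CC(=O)OC1O` differs from compound 2 by hydrogen in place of hydroxymethyl on a double-bonded ring carbon. Going by the values given here, no measured pair isolates this change, so no step beyond the scatter is expected in either direction. Compound 3 is therefore estimated at 1700 nM in this assay, within 600 nM to 5000 nM, an expected step of a 1.2-fold lower number from compound 2 to compound 3 (0.09 log units; within the scatter).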

Compound 3, half-maximal inhibitory concentration: 2160 nM
For compound 3 the middle estimate is 1.3-fold (0.10 log units) below the measured one; measured number inside the range.
By their numbers in this assay, from the lowest: compounds 1, 2 and 3 (each within the scatter of the next).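

In this assay, going by these compounds alone, hydrogen in place of hydroxymethyl on the double-bonded ring carbon gives a 1.0-fold higher number from compound 2 to compound 3 (0.01 log units; within the scatter), the first matched pair at this position, and it shows no change beyond the scatter with naphthalen-2-yl on the carbonyl carbon. Naphthalen-2-yl in place of 3-chlorophenyl on that carbonyl carbon gives a 1.8-fold higher number from compound 1 to compound 3 (0.26 log units; within the scatter), which also stays within the scatter. No supporting data bear on these results.

On these data alone, whether an aminomethyl group or a carboxylic acid on the same ring carbon would give a similar number remains open. So does the effect of hydroxymethyl when 3-chlorophenyl is present.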